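Adding a hydroxy to compound 2

The source may report more compounds than this note shows. Statements on the series, on what has been measured and on what is new or still open speak of the compounds shown alone.

- compound 1 `CCCn1c(-c2ccc(O)cc2)c(C)c2cc(O)ccc21` gives 7900 nM in the growth test
- compound 2 `Cc1c(-c2ccc(O)cc2)n(CCCCOc2ccccc2)c2ccccc12` gives 11000 nM in the growth test

In a functional assay on HeLa cells (Homo sapiens) for inhibition, read by trypan blue exclusion, with a stated time of 72 h (on this read-out lower numbers stand for stronger inhibition of growth and higher numbers for weaker inhibition of growth), compound 2 at 11000 nM lies within the usual scatter of compound 1 at 7900 nM and the two cannot be ranked. Compound 3 (`Cc1c(-c2ccc(O)cc2)n(CCCCOc2ccccc2)c2ccc(O)cc12`) is compound 2 with hydroxy in place of hydrogen on an aromatic carbon and has not yet been measured. Within the data shown here, no measured pair isolates this change, as compound 1 differs from compound 2 in more than one place. Among the measured compounds shown here, the only guide is compound 1 at 7900 nM which also carries a hydroxy on the shared core. A small step toward stronger inhibition of growth in this assay is therefore expected, possibly none beyond the scatter. The expected change is a 1.8-fold lower number from compound 2 to compound 3 (0.26 log units; within the scatter) on this estimate. For compound 3 the estimated value is 6000 nM with an expected range from 2000 nM to 14000 nM in this test.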

Compound 3, concentration for 50% growth inhibition: 4000 nM
Compound 3: the middle estimate sits 1.5-fold (0.18 log units) above what was measured; low and high end bracket the measured number.
By their numbers in this assay, from the lowest: compounds 3, 1 and 2 (each within the scatter of the next, the first and the last beyond it).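

In this assay, among these compounds, hydroxy in place of hydrogen on an aromatic carbon, meta to a fused ring and para to a fused ring, gives a 2.8-fold lower number from compound 2 to compound 3 (0.44 log units; beyond the scatter), the first step that isolates this change and one that clears the scatter. With this hydroxy present in both compounds, phenoxymethyl in place of hydrogen on a saturated chain carbon, three bonds along the chain from an aromatic nitrogen, gives a 2.0-fold lower number from compound 1 to compound 3 (0.30 log units; within the scatter), so the chain change cannot be ranked on these two values. No supporting data bear on the origin of the hydroxy step.

Open, as far as these compounds go, is whether methoxy, fluorine or an amine on the same aromatic carbon gives a comparable step. Also open, from the compounds shown here alone, is whether a longer chain or a terminal amine in place of the phenoxymethyl end alters the growth read-out.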